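This account rests on a few compounds, and the source may have more. Where it says the series, first, only, none or still open, it means among the compounds named here.

Working notes on the series. Of the compounds shown here, three on a shared core have numbers so far: compound 1 `CO[C@@H]1CC=C2NN(c3ccc(Cl)cc3)C(=O)C[C@]2(C)O1`, compound 2 `CO[C@@H]1CC=C2NN(c3cccnc3)C(=O)C[C@]2(C)O1` and compound 3 `CO[C@@H]1CC=C2NN(c3ccc(C)cc3)C(=O)C[C@]2(C)O1`. In a functional assay on DU-145 cells (Homo sapiens) for inhibition, read by sulforhodamine B assay, with a stated time of 48 h (a higher number here means a weaker inhibitor, a lower number a stronger inhibitor), compound 1 gives 24200 nM, compound 2 gives 16400 nM and compound 3 gives 23200 nM. Compound 3 therefore stands second highest of the three numbers, nearest to compound 1 and furthest from compound 2, with every gap inside the scatter, so no order among the three can be read from these values.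

Compound 4 `CO[C@@H]1CC=C2NN(c3cncnc3)C(=O)C[C@]2(C)O1` differs from compound 3 by pyrimidin-5-yl in place of 4-methylphenyl on an amide-type nitrogen in a ring. Among the compounds with values here, the steps that bear on this exchange are those that swapped the ring on the amide-type nitrogen: a 1.5-fold lower number from compound 1 to compound 2 (0.17 log units; within the scatter) and a 1.4-fold higher number from compound 2 to compound 3 (0.15 log units; within the scatter). Both put a nitrogen-bearing six-membered aromatic ring against a carbon-only one and both stayed within the scatter, as did a 1.0-fold lower number from compound 1 to compound 3 (0.02 log units; within the scatter). Pyrimidin-5-yl adds a second ring nitrogen, but nothing measured here separates one such ring from another, so for compound 4 no step beyond the scatter is expected in this assay, in either direction. The expected step of a 1.2-fold lower number from compound 3 to compound 4 (0.09 log units; within the scatter) is accordingly small. Compound 4 is estimated at 19000 nM, with a range from 8000 nM to 45000 nM.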

Compound 4, half-maximal inhibitory concentration: 17100 nM
Compound 4: middle estimate off by 1.1-fold (0.05 log units), on the high side; the measured number falls inside the stated range.
By their numbers in this assay, from the lowest: compounds 2, 4, 3 and 1 (each within the scatter of the next).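

In this assay, the ring on the amide-type nitrogen now tolerates a third kind of six-membered aromatic ring without any step beyond the scatter: a 1.4-fold lower number from compound 3 to compound 4 (0.13 log units; within the scatter), a 1.0-fold higher number from compound 2 to compound 4 (0.02 log units; within the scatter) and a 1.4-fold lower number from compound 1 to compound 4 (0.15 log units; within the scatter). The new element is pyrimidin-5-yl, a ring with 2 hetero atoms and 2 hydrogen-bond acceptors, and against both carbon-only rings and pyridin-3-yl it gives no readable change, so these four compounds do not separate the rings at this position. No measurement is available that explains these values.

On these data alone, all four groups are six-membered aromatic rings bonded directly to that nitrogen, so it remains open how a benzyl group, a longer alkyl chain or a ring carrying an amine or a carboxylic acid would behave there. As far as these compounds go, the methoxy and methyl groups are the same throughout, so the effect of changing them also remains open.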